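A few compounds are considered here, and "the series" means these few. Any claim that something is new, unique, unknown or untested is made for them only; others in the source may bear on it.

Measured compounds and their permeability numbers:

- compound 1, `COc1ccccc1Oc1ccc2c(NCCCNCc3ccco3)ccnc2c1`: 317 10^-6 cm/s
- compound 2, `COc1ccc(F)cc1CNCCCNc1ccnc2cc(CCc3ccccc3)ccc12`: 23 10^-6 cm/s
- compound 3, `COc1ccc(F)cc1CNCCCNc1ccnc2cc(Cc3ccccc3)ccc12`: 23 10^-6 cm/s

Permeability here was measured in an ADME assay for permeability, using PAMPA, with a stated time of 30 min, at pH 7.4; on this read-out lower numbers stand for lower permeability and higher numbers for higher permeability. Among the three measured compounds, compound 1 stands highest: its number lies well beyond the scatter above those of compound 2 and compound 3, which sit close to each other. For the measured compounds named here, the only one-place step among measured compounds, no change at the digits printed from compound 2 to compound 3 (within the scatter), swaps phenyl for benzyl on a saturated chain carbon bound to an aromatic carbon and leaves this assay unchanged within the scatter.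

Compound 4, `c1coc(CNCCCNc2ccnc3cc(CC4CCCCC4)ccc23)c1`, has not yet been measured. It differs from compound 1 in one place: cyclohexylmethyl in place of 2-methoxyphenoxy on an aromatic carbon. Going by the values given here, no measured step tests this particular exchange, so the step between compound 2 and compound 3 is the closest guide, and it shows that a change at a nearby position of the shared core can pass without a visible effect. On that basis compound 4 is expected to stay near compound 1, with a step of a 1.3-fold lower number from compound 1 to compound 4 (0.10 log units; within the scatter) in this assay, which would be within the scatter.

The estimate for compound 4 is therefore 250 10^-6 cm/s, with a range from 100 10^-6 cm/s to 600 10^-6 cm/s.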

Compound 4, apparent permeability: 23 10^-6 cm/s
The estimate for compound 4 lay 11-fold (1.04 log units) above the measured number; the whole stated range lies above it.
By their numbers in this assay, from the lowest: compounds 2, 3 and 4 (each within the scatter of the next); then compound 1.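

In this assay, the exchange of 2-methoxyphenoxy for cyclohexylmethyl on this aromatic carbon of the shared core gives a 14-fold lower number from compound 1 to compound 4 (1.14 log units; beyond the scatter), so what sits at this place can move the number well past the usual scatter, which the earlier step, no change at the digits printed from compound 2 to compound 3 (within the scatter), gave no sign of. This single exchange alters several things at once: the leaving group has 9 heavy atoms, a six-membered aromatic ring and 2 hydrogen-bond acceptors, while the entering group has 7 heavy atoms, a six-membered non-aromatic ring and 0 hydrogen-bond acceptors. No separate measurement points to which of these differences accounts for the lower number.

As far as these compounds go, one step cannot separate the ring type from the oxygen atoms, so it remains open which of them matters here. A cyclohexyloxy group at this aromatic carbon would keep the linking oxygen with the non-aromatic ring, and a plain phenoxy group would keep the aromatic ring without the methoxy, so each would test one part of the change.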